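Swapping the Fluorinated Group on a Weak Antiproliferative

A few compounds are considered here, and "the series" means these few. Any claim that something is new, unique, unknown or untested is made for them only; others in the source may bear on it.

Compound 1 `O=C1O/C(=C\Cn2cnc3c(F)nc(F)c(Cl)c32)C(OCc2ccccc2)=C1OCc1ccccc1`: 78000 nM
Compound 2 `O=C1O/C(=C\Cn2cnc3ccn(C/C=C4\OC(=O)C(OCc5ccccc5)=C4OCc4ccccc4)c3c2=O)C(OCc2ccccc2)=C1OCc1ccccc1`: 26200 nM
Compound 3 `O=C1NC(O)(CCn2cnc3cc[nH]c3c2=O)C(OCc2ccccc2)=C1OCc1ccccc1`: 36600 nM

In a functional assay on MIA PaCa-2 cells (Homo sapiens) for antiproliferative activity, read by MTT assay, with a stated time of 72 h (on this read-out higher numbers stand for weaker inhibition and lower numbers for stronger inhibition), compound 1 gives 78000 nM, the highest number of the three and so the weakest inhibition. Compound 4 `O=C1O/C(=C\Cn2cnc3cc[nH]c3c2=O)C(OCc2ccccc2)=C1OCc1ccccc1` has not yet been measured. It differs from compound 1 on a saturated chain carbon bound to a double-bonded chain carbon: a group of 10 heavy atoms (6 carbon, 3 nitrogen, 1 oxygen; one five-membered aromatic ring with 1 hetero atom, one six-membered aromatic ring with 2 hetero atoms) in place of a group of 12 heavy atoms (6 carbon, 3 nitrogen, 2 fluorine, 1 chlorine; one five-membered aromatic ring with 2 hetero atoms, one six-membered aromatic ring with 1 hetero atom), on a saturated chain carbon bound to a double-bonded chain carbon. Going by the values given here, no measured pair isolates this swap. The expectation therefore rests mainly on compound 3, which carries the incoming group on a different chain and gives 36600 nM. The expected change is a modest move towards stronger inhibition, a 2.6-fold lower number from compound 1 to compound 4 (0.41 log units; beyond the scatter). For compound 4, the estimated value is 30000 nM, with an expected range of 11000 nM to 75000 nM.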

Compound 4, half-maximal inhibitory concentration: > 100000 nM
Compound 4 was reported as a limit; the forecaster's own chance of this, stated with the estimate: 10%; middle value at least 3.3-fold (0.52 log units) away from the limit.
By their numbers in this assay, from the lowest: compounds 2 and 3 (each within the scatter of the next); then compound 1. At a limit, above all of these: compound 4.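

In this assay compound 4 gives > 100000 nM as a limit of the assay, not a number. On a saturated chain carbon bound to a double-bonded chain carbon, replacing the fluorine- and chlorine-bearing group with the smaller group containing oxygen shows an at least 1.2-fold higher number from compound 1 to compound 4 (0.10 log units; that floor lies within the scatter) as the only size that can be read, and the swap brings no gain in inhibition. The full size of the step cannot be read.

On these data alone, whether an amine or a carboxylic acid on this chain carbon would give stronger inhibition stays open. Also open, as far as these compounds go, is whether the chlorine or the fluorines of compound 1 matter individually.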